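The compounds below may be only part of what the source reports. "The series", "measured", "known", "first", "only" and "open" are said of these compounds alone.

Three compounds share one core and differ only in the ring at the far end of the urea. Compound 1 `O=C(Nc1cccc(CNc2nccnc2Cl)c1)Nc1ccccc1Cl` carries a 2-chlorophenyl group there and gives 7130 nM in a functional assay on MGC-803 cells (Homo sapiens) for antiproliferative activity, read by MTT assay, with a stated time of 48 h; on this read-out higher numbers stand for weaker inhibition and lower numbers for stronger inhibition. Compound 2 `O=C(Nc1ccccc1)Nc1cccc(CNc2nccnc2Cl)c1` carries a plain phenyl group and gives 16300 nM in this assay. Compound 3 `O=C(Nc1ccc(Cl)cc1)Nc1cccc(CNc2nccnc2Cl)c1` carries a 4-chlorophenyl group and gives 4980 nM in this assay, the lowest of the three numbers; its gap to compound 1 lies within the scatter, while its gap to compound 2 lies beyond it.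

Compound 4 `O=C(Nc1cccc(CNc2nccnc2Cl)c1)Nc1ccc(Cl)c(Cl)c1` is the next step: chloro in place of hydrogen on an aromatic carbon. The measured steps that touch a chloro group point the same way. Adding one gave a 3.3-fold lower number from compound 2 to compound 3 (0.51 log units; beyond the scatter); removing one gave a 2.3-fold higher number from compound 1 to compound 2 (0.36 log units; beyond the scatter). Moving the chloro group from one position to another, however, gave only a 1.4-fold lower number from compound 1 to compound 3 (0.16 log units; within the scatter). A second chloro group, now placed ortho to a chloro group already present, is therefore expected to lower the number at most modestly, and possibly not beyond the scatter; the step is estimated as a 1.6-fold lower number from compound 3 to compound 4 (0.19 log units; within the scatter).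

Compound 4 is therefore estimated to give 3200 nM in this assay, with a likely range from 1400 nM to 7500 nM.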

Compound 4, half-maximal inhibitory concentration: 4970 nM
The estimate for compound 4 lay 1.6-fold (0.19 log units) below the measured number, and the stated range covers the measured number.
By their numbers in this assay, from the lowest: compounds 4, 3 and 1 (each within the scatter of the next); then compound 2.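

Placing a second chloro group on the 4-chlorophenyl ring, ortho to the chloro group already there and meta to a large group, produced no readable change: the result is a 1.0-fold lower number from compound 3 to compound 4 (0.00 log units; within the scatter), so the first chloro group shifted the number beyond the scatter and this one did not. The 3,4-dichlorophenyl group still gives a 3.3-fold lower number from compound 2 to compound 4 (0.52 log units; beyond the scatter) against plain phenyl, which matches the step already seen with one chloro group, a 3.3-fold lower number from compound 2 to compound 3 (0.51 log units; beyond the scatter), while against the 2-chlorophenyl group it gives only a 1.4-fold lower number from compound 1 to compound 4 (0.16 log units; within the scatter). Taking a chloro group away looks larger on one compound than on the other, yet these two steps cannot be told apart: the same change on two cores in this assay, a 2.3-fold higher number (0.36 log units; beyond the scatter) from compound 1 to compound 2 and a 1.0-fold higher number (0.00 log units; within the scatter) from compound 4 to compound 3, 2.3-fold (0.36 log units) apart, within the scatter of two such steps.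

Among these compounds, what a methoxy group, a trifluoromethyl group or an amine would do on this ring remains open, since chloro is the only group other than hydrogen seen here. Also open, on these data alone, is whether any change at this end of the urea can bring the number clearly lower than the values of compound 3 and compound 4 in this assay.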